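A few compounds are considered here, and "the series" means these few. Any claim that something is new, unique, unknown or untested is made for them only; others in the source may bear on it.

Working notes on the series. In a functional assay on RS4-11 cells (Homo sapiens) for inhibition, read by CCK-8 assay, with a stated time of 48 h, tested at 20 uM (a lower number here means less inhibition of growth, a higher number more inhibition of growth at the concentration tested), compound 1 (`N#C/C(=C\c1ccccc1OS(=O)(=O)c1ccccc1[N+](=O)[O-])C(=O)Nc1nnc(Cc2cccc3ccccc23)s1`) gives 66%, compound 2 (`Cc1ccc(Cc2nnc(NC(=O)/C(C#N)=C/c3ccccc3OS(=O)(=O)c3ccc(C)cc3)s2)cc1`) gives 66% and compound 3 (`Cc1ccc(Cc2nnc(NC(=O)/C(C#N)=C/c3ccccc3OS(=O)(=O)c3ccc([N+](=O)[O-])cc3)s2)cc1`) gives 64%. All three values lie within the scatter of each other, so compound 3 stands level with the other two and holds no distinct rank.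

The next compound is compound 4 (`Cc1ccc(Cc2nnc(NC(=O)/C(C#N)=C/c3ccccc3OS(=O)(=O)c3ccccc3[N+](=O)[O-])s2)cc1`), and the change from compound 3 is 2-nitrophenyl in place of 4-nitrophenyl on a sulfonyl sulfur. Within the data shown here, the only measured step that bears on it is a number 2 percentage points lower from compound 2 to compound 3 (within the scatter), which also alters the aromatic ring on the sulfonyl sulfur and stays within the scatter. Compound 1 already carries 2-nitrophenyl on a sulfonyl sulfur and gives 66%, although the rest of its structure differs from that of compound 4. Among the measured compounds shown here, no measured pair isolates this exact swap. No change beyond the scatter is therefore expected in this assay. The expected step is a number 1 percentage points higher from compound 3 to compound 4 (within the scatter). For compound 4 the estimated value is 65%, with an expected range of 54% to 76%.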

Compound 4, percent growth inhibition at one concentration: "not active" (no number reported)
Compound 4 has no reported number here, so the estimate cannot be set against anything.
By their numbers in this assay, from the lowest: compounds 3, 1 and 2 (each within the scatter of the next).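

Among these compounds, compound 4 is reported as "not active" in this assay with no number, so no step from compound 3 to compound 4 can be read. The compounds shown leave open how 2-nitrophenyl in place of 4-nitrophenyl on a sulfonyl sulfur affects growth inhibition. No evidence bears on this result.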